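Fluoro in Two Places: Carrying a Step to a New Core

The source may report more compounds than this note shows. Statements on the series, on what has been measured and on what is new or still open speak of the compounds shown alone.

Of the compounds shown here, three have been measured in an ADME assay on microsomes from liver (Homo sapiens) for metabolic stability, tested at 2.5 uM; on this read-out higher numbers stand for fast clearance and lower numbers for slow clearance. Compound 1 `Fc1cc(Cl)ccc1-c1ccc(Cn2nnc3ccccc32)cn1` gives 0.01 mL/min/g in this assay . Compound 2 `Fc1ccc2c(c1)nnn2Cc1ccc(-c2ccc(Cl)cc2F)nc1` gives 0.1 mL/min/g, and compound 3 `Brc1cccc2c1nnn2Cc1ccccc1` gives 4.7 mL/min/g, the highest of the three numbers and beyond the scatter from both others.

Compound 2 differs from compound 1 by fluoro in place of hydrogen on an aromatic carbon, and that change produced a 10-fold higher number from compound 1 to compound 2 (1.00 log units; beyond the scatter). Compound 4 `Fc1ccccc1Cn1nnc2c(Br)cccc21`, not yet measured, differs from compound 3 by fluoro in place of hydrogen on an aromatic carbon. The two changes are the same kind of change but not the same: in compound 2 the fluoro sits on a ring that is part of a fused or bridged system of two rings, meta to a fused ring and para to a fused ring, while in compound 4 it sits on a ring of carbon only, ortho to a large group. The difference between the core of compound 1 and the core of compound 3 is not broken down here.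

For compound 4 the step is expected to be a 1.3-fold higher number from compound 3 to compound 4 (0.11 log units; within the scatter), smaller than the earlier one, because compound 3 already stands at 4.7 mL/min/g, near the top of what this assay reports, and the fluoro enters a different ring. The estimate for compound 4 is 6 mL/min/g, expected to fall between 2.5 mL/min/g and 14 mL/min/g.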

Compound 4, intrinsic clearance in a liver preparation (reported as CLH), per the amount of preparation that the assay uses: 0.2 mL/min/g
Estimate against measurement, compound 4: 30-fold (1.48 log units) above; measured number outside the range, below it.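

In this assay, fluoro in place of hydrogen on an aromatic carbon of a six-membered aromatic ring of carbon only, ortho to a large group, gave a 24-fold lower number from compound 3 to compound 4 (1.37 log units; beyond the scatter), so compound 4 is cleared more slowly than its parent on this read-out. Set beside the earlier step, the same kind of change moved the number in opposite directions on the two cores, and the gap between the two steps is far from trivial: the same change on two cores in this assay, a 10-fold higher number (1.00 log units; beyond the scatter) from compound 1 to compound 2 and a 24-fold lower number (1.37 log units; beyond the scatter) from compound 3 to compound 4, 240-fold (2.37 log units) apart, beyond the scatter of two such steps

Among the compounds shown here, this shows that the result of adding a fluoro cannot simply be carried from one core to another, since neither the direction nor the size of the step held, but it does not show why, as each core offers only one matched pair and the fluoro sits in a different kind of ring in each pair, so the core and the place of the fluoro cannot be told apart.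

On these data alone, it remains open whether the fall seen in compound 4 belongs to fluoro itself or would also come with another small group at the same place, such as a methyl or a methoxy group. As far as these compounds go, it is also open how a fluoro on the fused ring of compound 3 would behave, which would put the two cores on a more equal footing.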